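Urea aryl trimming in a pyrazole growth-inhibitor series

The compounds below may be only part of what the source reports. "The series", "measured", "known", "first", "only" and "open" are said of these compounds alone.

For the measured compounds named here, compound 1 `COc1cc(-c2nn(-c3cccc(NC(=O)Nc4cc(C(F)(F)F)cc(C(F)(F)F)c4)c3)cc2-c2ccncc2)ccc1Cl` and compound 2 `O=C(Nc1cccc(-n2cc(-c3ccncc3)c(-c3ccc(Cl)c(O)c3)n2)c1)Nc1ccc(Cl)c(Cl)c1` are the two members measured so far in a functional assay on SK-MEL-5 cells (Homo sapiens) for inhibition, read by sulforhodamine B assay, with a stated time of 48 h; a lower number here means a stronger inhibitor of growth, a higher number a weaker inhibitor of growth. Compound 1 gives 1360 nM and compound 2 gives 1160 nM; the two numbers lie within the scatter of each other, so neither can be set apart. Compound 3 `COc1cc(-c2nn(-c3cccc(NC(=O)Nc4cccc(C(F)(F)F)c4)c3)cc2-c2ccncc2)ccc1Cl` is not yet measured. It differs from compound 1 by hydrogen in place of trifluoromethyl on an aromatic carbon. Going by the values given here, no measured pair shows this change. The step is expected to be small, toward a somewhat higher number, at most at the edge of the scatter: a 1.5-fold higher number from compound 1 to compound 3 (0.17 log units; within the scatter). Compound 3 is therefore estimated at 2000 nM, within 700 nM to 6000 nM.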

Compound 3, concentration for total growth inhibition: 1390 nM
For compound 3 the middle estimate is 1.4-fold (0.16 log units) above the measured one, within the range that was stated.
By their numbers in this assay, from the lowest: compounds 2, 1 and 3 (each within the scatter of the next).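

In this assay, for the compounds shown here, hydrogen in place of trifluoromethyl on an aromatic carbon gives a 1.0-fold higher number from compound 1 to compound 3 (0.01 log units; within the scatter), the first measured pair for this change. At this position, one trifluoromethyl group can therefore be exchanged for hydrogen with no readable change in this growth read-out. No measurement at hand explains this result.

Going by these compounds, whether the remaining trifluoromethyl can also be replaced by hydrogen, or whether an amine or carboxylic acid would be tolerated at this position, stays open. The step rests on a single pair, so its transfer to the core of compound 2 is also unknown.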